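Inverting Two Stereocentres in a Spirocyclic Substance-P Receptor Ligand

A few compounds are considered here, and "the series" means these few. Any claim that something is new, unique, unknown or untested is made for them only; others in the source may bear on it.

Measured compounds:
Compound 1, `Fc1ccc([C@@H]2NCCO[C@@]23CC[C@@H](c2ccccc2C(F)(F)F)CO3)cc1`: 28 nM
Compound 2, `Fc1ccc([C@@H]2NCCO[C@@]23C[C@@H](c2ccccc2C(F)(F)F)CO3)cc1`: 24 nM
Compound 3, `COc1cccc(-n2nnnc2C(F)(F)F)c1[C@H]1CO[C@@]2(C1)OCCN[C@H]2c1ccc(F)cc1`: 0.1 nM

Of the compounds shown here, three have been tested in an assay on CHO cells for displacement of a labelled ligand from Substance-P receptor (Homo sapiens); a lower number here means a stronger inhibitor, a higher number a weaker inhibitor. Compound 1 gives the highest number of the three in this assay, 28 nM. Compound 2, which is also measured in this assay and gives 24 nM, sits close to it, and the two values fall within the usual scatter of the measurement, so nothing separates them. Compound 3 gives 0.1 nM in this assay, a far lower number and well beyond the scatter, but it differs from compound 1 in many places at once, so no single change can be held responsible.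

Compound 4, `Fc1ccc([C@@H]2NCCO[C@]23CC[C@H](c2ccccc2C(F)(F)F)CO3)cc1`, is the next compound to be measured. Compared with compound 1, (the two compounds have the same atoms and bonds and differ only in configuration as drawn: 2 of 3 stereo elements differ; a stereocentre at a saturated ring carbon is drawn S in compound 1 and R in compound 4; a stereocentre at a saturated ring carbon is drawn S in compound 1 and R in compound 4). The atoms and bonds are identical; only the three-dimensional arrangement at two of the three saturated ring carbons is changed, so compound 4 is a diastereomer of compound 1.

Among the measured compounds shown here, no pair of measured compounds here differs only in configuration, so there is no step in this assay to lean on. Changes of configuration in compounds of this kind commonly shift the number by more than the scatter, and in no predictable direction from these data alone. Since compound 1 already gives the highest number of the three, a weaker result for compound 4 is expected, with wide uncertainty: compound 4 is estimated to give 150 nM in this assay, within the range 20 nM to 1500 nM, which corresponds to an expected step of a 5.4-fold higher number from compound 1 to compound 4 (0.73 log units; beyond the scatter).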

Compound 4, half-maximal inhibitory concentration: 400 nM
Compound 4: the middle estimate sits 2.7-fold (0.43 log units) below what was measured, and the stated range covers the measured number.
By their numbers in this assay, from the lowest: compound 3; then compounds 2 and 1 (each within the scatter of the next); then compound 4.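

In this assay, the configuration of the shared structure matters a great deal: there is a 14-fold higher number from compound 1 to compound 4 (1.15 log units; beyond the scatter), a large step. Among the compounds shown here, this is the first comparison in the set that rests on a single kind of change, since the earlier compounds differed in many places at once or stayed within the scatter of each other, and it shows that the arrangement at these two saturated ring carbons is not a detail this measurement overlooks. The step can be put down to configuration alone, with no group entering or leaving, because of this: the fact that compounds 1 and 4 differ only in the configuration as drawn.

How the step is shared between the two inverted stereocentres remains open, as both change together here, and either one might account for most of it or both might contribute. Also open, going by these compounds, is whether the same sensitivity to configuration would hold if a nitrile stood in place of the trifluoromethyl group, or in a structure carrying the tetrazole-bearing aromatic group of compound 3.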